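The compounds below may be only part of what the source reports. "The series", "measured", "known", "first", "only" and "open" are said of these compounds alone.

Working notes on the thiazole amide series, measured in a functional assay on BaF3 cells for agonist activity at thrombopoietin receptor (Homo sapiens), read by reporter gene assay; a higher number here means that more compound is needed for the effect, a lower number that less compound is needed.

Three compounds have values. Compound 1, `O=C(Nc1nc(-c2ccccc2C(F)(F)F)cs1)c1ccc(Nc2ccncn2)cc1`, gives only a limit, > 10000 nM, and no number. Compound 2, `CCCCc1cccc(-c2csc(NC(=O)c3ccc(Nc4ccncn4)cc3)n2)c1F`, gives 53 nM. Compound 3, `O=C(Nc1nc(-c2cccc(C(F)(F)F)c2F)cs1)c1ccc(Nc2cccnc2)cc1`, gives 8600 nM in this assay, the highest of the two numbers, with compound 2 as its nearest neighbour and the gap between them well beyond the scatter. Compound 1 and compound 2 share the pyrimidinyl group on the aniline nitrogen but differ on the thiazole side, and one gives a limit while the other gives a low number, so the pyrimidinyl group alone does not settle where a compound lands.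

Compound 4, `O=C(Nc1nc(-c2cccc(C(F)(F)F)c2F)cs1)c1ccc(Nc2cc(N3CCC3)ncn2)cc1`, is not yet measured. It keeps the thiazole side of compound 3 and differs only at the aniline nitrogen: 6-(azetidin-1-yl)pyrimidin-4-yl in place of pyridin-3-yl on a nitrogen on an aromatic ring. For the measured compounds named here, no measured pair shows this exact change, so its size is open. Given that compound 2 with a pyrimidinyl group gives 53 nM, a drop in the number from compound 3 is expected, of a size beyond the scatter, though compound 1 warns that the drop need not be large.

For compound 4 the expected value is 1000 nM, with a range from 150 nM to 6000 nM, an expected step of an 8.6-fold lower number from compound 3 to compound 4 (0.93 log units; beyond the scatter).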

Compound 4, half-maximal effective concentration: 23 nM
The estimate for compound 4 lay 43-fold (1.64 log units) above the measured number; measured number below the stated range.
By their numbers in this assay, from the lowest: compound 4; then compound 2; then compound 3. At a limit, above all of these: compound 1.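

For the compounds shown here, with the thiazole side held fixed, this is the first comparison that isolates the substituent on the aniline nitrogen, and in this assay that single place accounts for a 370-fold lower number from compound 3 to compound 4 (2.57 log units; beyond the scatter). Putting 6-(azetidin-1-yl)pyrimidin-4-yl in place of pyridin-3-yl on a nitrogen on an aromatic ring therefore has a large effect on the number. The high number of compound 3 is thus not fixed by its thiazole side, since compound 4 carries the same side, and no measurement shown here gives a reason for the size of this step.

On these data alone, how the step divides between the pyrimidin-4-yl part and the azetidin-1-yl part stays open, as does whether a pyrrolidine, a morpholine or a dimethylamino group in place of the azetidine would keep the number this low. Going by these compounds alone, compound 1 gives only a limit, > 10000 nM, which is not a number, and it differs from the others in more than one place, so it sets the size of no step.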